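Notes on the amine substituent, compound 2 to compound 3

The compounds below may be only part of what the source reports. "The series", "measured", "known", "first", "only" and "open" are said of these compounds alone.

In a functional assay on ECa-109 cells for inhibition, with ECa-109 cell line (Homo sapiens) as the target, read by sulforhodamine B assay (on this read-out higher numbers stand for weaker inhibition and lower numbers for stronger inhibition), compound 1 `O=C1C(NC2CCCC2)=CC(=O)c2c1nc1n2[C@H]2OC[C@@H](O)[C@H]2OC1` gives only a limit, > 16000 nM. That limit is described by the limit of > 16000 nM in this assay, at which 1 of the 2 values shown sits. Going by the values given here, compound 2 `O=C1C=C(Nc2cccc(F)c2)C(=O)c2c1nc1n2[C@H]2OC[C@@H](O)[C@H]2OC1` gives 7030 nM in this assay, the only number the set shows so far. Compound 3 `Cc1ccc(NC2=CC(=O)c3nc4n(c3C2=O)[C@H]2OC[C@@H](O)[C@H]2OC4)cc1C` carries 3,4-dimethylphenyl in place of 3-fluorophenyl on an amine nitrogen. Among the compounds with values here, no step between two measured compounds exists here, so nothing measured sets the size of this change; the expected step of a 1.3-fold lower number from compound 2 to compound 3 (0.11 log units; within the scatter) is taken to lie within the scatter. Compound 3 is therefore estimated at 5500 nM in this assay, with a range from 2000 nM to 15000 nM.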

Compound 3, half-maximal inhibitory concentration: 2820 nM
For compound 3 the middle estimate is 2.0-fold (0.29 log units) above the measured one; low and high end bracket the measured number.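

In this assay the change on this amine nitrogen reads as a 2.5-fold lower number from compound 2 to compound 3 (0.40 log units; beyond the scatter) and gives the first measured size for a change at this position. The aryl group here is therefore not silent: 3,4-dimethylphenyl and 3-fluorophenyl are told apart on the shared core, although a single pair sets no trend. No measured property bears on the origin of this step.

Open, as far as these compounds go, is whether one methyl alone, as in 3-methylphenyl or 4-methylphenyl, carries the step. Also open, from the compounds shown here alone, is how a pyridyl ring or a benzyl group on the same nitrogen would read.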